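From Bromo to Trifluoromethyl: A Small Expected Step

The source may hold more compounds than are shown below. What is called first, only, known or untested is meant among the compounds shown, and "the series" means these compounds.

Two related compounds have been measured so far in a functional assay on MCF7 cells (Homo sapiens) for antiproliferative activity, read by MTT assay, with a stated time of 24 h; a lower number here means a stronger inhibitor, a higher number a weaker inhibitor. Compound 1 (`Cc1ccc(-c2nn(-c3ccccc3)cc2-c2nc3ccccc3n2S(=O)(=O)c2ccc(C(F)(F)F)cc2)cc1`) gives 2340 nM, and compound 2 (`O=S(=O)(c1ccc(Br)cc1)n1c(-c2cn(-c3ccccc3)nc2-c2ccc(F)cc2)nc2ccccc21`) gives 2630 nM, so these two values lie within the usual scatter of each other. Compound 3 (`O=S(=O)(c1ccc(C(F)(F)F)cc1)n1c(-c2cn(-c3ccccc3)nc2-c2ccc(F)cc2)nc2ccccc21`) keeps everything in compound 2 except one group: trifluoromethyl in place of bromo on an aromatic carbon, para to a large group (trifluoromethyl in place of bromo on an aromatic carbon). Among the measured compounds shown here, no measured pair shows this swap alone. The nearest evidence is compound 1 at 2340 nM, which already carries the 4-(trifluoromethyl)phenyl group but differs from compound 3 elsewhere. On that basis, no change beyond the scatter is expected in this assay. The expected step of a 1.1-fold lower number from compound 2 to compound 3 (0.04 log units; within the scatter) is therefore small. For compound 3 the estimated value is 2400 nM, with an expected range of 1100 nM to 5000 nM.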

Compound 3, half-maximal inhibitory concentration: 1580 nM
Estimate against measurement, compound 3: 1.5-fold (0.18 log units) above; the range from low to high includes it.
By their numbers in this assay, from the lowest: compounds 3, 1 and 2 (each within the scatter of the next).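

In this assay the swap of bromo for trifluoromethyl, on an aromatic carbon para to a large group, can now be read on its own. It gives a 1.7-fold lower number from compound 2 to compound 3 (0.22 log units; within the scatter) and so shows no measurable difference between these two groups at this position. The change of fluoro in place of methyl on an aromatic carbon gives a 1.5-fold lower number from compound 1 to compound 3 (0.17 log units; within the scatter) and is equally small, while no measurement shown here bears on what lies behind either result.

Bromo and trifluoromethyl are the only groups compared at this position, and each counts 0 hydrogen-bond donors and 0 hydrogen-bond acceptors. As far as these compounds go, whether an amine, a carboxylic acid or a longer chain in the same place would move the number beyond the scatter remains open.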